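Swapping Nitro for Methyl on the Far Anilide Ring

The compounds below may be only part of what the source reports. "The series", "measured", "known", "first", "only" and "open" are said of these compounds alone.

Of the compounds shown here, three on the shared core have been tested. Compound 1, `Nc1ccccc1NC(=O)CCCNCC(=O)Nc1ccc(Cl)cc1`, gives 75% in a functional assay on the whole organism (Ehrlich cells, Mus musculus) for antiproliferative activity, with a stated time of 24 h, at a dose of 0.2 mmol/kg by the intraperitoneal route; on this read-out lower numbers stand for less inhibition and higher numbers for more inhibition at the one dose given (going by the name of the read-out). Compound 2, `Nc1ccccc1NC(=O)CCCNCC(=O)Nc1ccc(Br)cc1`, gives 68.7%. Compound 3, `Nc1ccccc1NC(=O)c1ccc(NCC(=O)Nc2ccc([N+](=O)[O-])cc2)cc1`, gives 77.5%, the highest of the three numbers, although its gaps to compound 1 and compound 2 both lie within the usual scatter. Compound 4, `Cc1ccc(NC(=O)CNc2ccc(C(=O)Nc3ccccc3N)cc2)cc1`, is not yet measured; it differs from compound 3 by methyl in place of nitro on an aromatic carbon. For the measured compounds named here, the only measured step, a number 6.3 percentage points lower from compound 1 to compound 2 (within the scatter), also exchanged one group for another on an aromatic carbon and stayed within the scatter. Going by the values given here, no measured step exchanges nitro for methyl. Compound 4 is therefore expected to show a number 4.5 percentage points lower from compound 3 to compound 4 (within the scatter), nothing beyond the scatter. Compound 4 is estimated at 73%, ranging from 55% to 88%.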

Compound 4, a percentage reported as inhibition, in the whole organism at one dose (the size of the read-out at that dose, not a potency): 25.2%
For compound 4 the middle estimate is 47.8 percentage points above the measured one, outside the stated range (below it).
By their numbers in this assay, from the lowest: compound 4; then compounds 2, 1 and 3 (each within the scatter of the next).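

In this assay, methyl in place of nitro on the aromatic ring gives a number 52.3 percentage points lower from compound 3 to compound 4 (beyond the scatter) and so shows that this position is far from indifferent to the group it carries. The earlier exchange of bromo for chloro gave a number 6.3 percentage points lower from compound 1 to compound 2 (within the scatter) and offered no sign of a change this large. Nothing shown here gives a reason for the drop. On these data alone, it remains open how an amine, a methoxy group or a plain hydrogen would fare at this place on the shared core, so it cannot yet be said whether nitro stands out or methyl falls short.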